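The compounds below may be only part of what the source reports. "The series", "measured", "known", "first", "only" and "open" are said of these compounds alone.

Measured in a functional assay on HepG2 cells (Homo sapiens) for inhibition, read by MTT assay, with a stated time of 48 h; on this read-out higher numbers stand for weaker inhibition and lower numbers for stronger inhibition:
Compound 1 `COc1cc(C(=O)/C=C/c2ccc(Br)cc2)cc(OC)c1OC`: 80000 nM
Compound 2 `COc1cc(C(=O)/C=C/c2ccccc2C=O)cc(OC)c1OC`: > 100000 nM

On these numbers, compound 2 has no measured value, and its > 100000 nM is a limit. Compound 3 `COc1cc(C(=O)/C=C/c2ccc(C=O)cc2)cc(OC)c1OC` differs from compound 2 as follows: 4-formylphenyl in place of 2-formylphenyl on a double-bonded chain carbon bound to a double-bonded chain carbon. In words, it has 4-formylphenyl in place of 2-formylphenyl on a double-bonded chain carbon bound to a double-bonded chain carbon.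

Going by the values given here, one measured step bears on this change, an at least 1.2-fold higher number from compound 1 to compound 2 (0.09 log units; that floor lies within the scatter). It exchanges 4-bromophenyl for 2-formylphenyl, and it does not show the effect of the exchange now in question. A small step towards a lower number is therefore expected in this assay, and it may well stay within the scatter. The nearest actual number is that of compound 1, at 80000 nM, so the expectation is anchored there. The expected change is an at least 1.4-fold lower number from compound 2 to compound 3 (0.15 log units; that floor lies within the scatter). The estimate for compound 3 is 70000 nM, with an expected range of 25000 nM to 130000 nM.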

Compound 3, half-maximal inhibitory concentration: > 100000 nM
Compound 3 gave a limit, no number (the forecaster's own chance of this, stated with the estimate: 35%); middle value at least 1.4-fold (0.15 log units) away from the limit.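

In this assay compound 3 gives > 100000 nM, which is a limit of the assay and not a number. With formyl in place of bromo on an aromatic carbon, the result is an at least 1.2-fold higher number from compound 1 to compound 3 (0.09 log units; that floor lies within the scatter), so 4-formylphenyl is not shown to differ from 4-bromophenyl at this place. The step between 2-formylphenyl and 4-formylphenyl cannot be read, and what the change of formyl position does to the read-out stays hidden behind the limit that compound 2 and compound 3 share: the limit of > 100000 nM in this assay, at which 2 of the 3 values shown sit.

On these data alone, how far compound 2 and compound 3 actually lie from each other remains open. As far as these compounds go, it is also open whether an amine or a carboxylic acid on the phenyl ring, in place of the formyl, would give a measured number clearly apart from that of compound 1.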